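Quinoline thiosemicarbazones: from substituted anilines to a benzylamine

A few compounds are considered here, and "the series" means these few. Any claim that something is new, unique, unknown or untested is made for them only; others in the source may bear on it.

Measured in a functional assay on SGC-7901 cells (Homo sapiens) for antiproliferative activity, read by sulforhodamine B assay, with a stated time of 72 h; a higher number here means a weaker inhibitor, a lower number a stronger inhibitor:
- compound 1 `Fc1cccc(NC(=S)N/N=C/c2ccc3ccccc3n2)c1`: 79900 nM
- compound 2 `S=C(N/N=C/c1ccc2ccccc2n1)Nc1cccc(Cl)c1`: 61300 nM
- compound 3 `Cc1cccc(NC(=S)N/N=C/c2ccc3ccccc3n2)c1`: > 100000 nM

All three share the same core and differ only in one group on the ring attached to the thiourea nitrogen. The step of a 1.3-fold lower number from compound 1 to compound 2 (0.12 log units; within the scatter) and the step of an at least 1.2-fold higher number from compound 1 to compound 3 (0.09 log units; that floor lies within the scatter) both stay within the scatter, as does an at least 1.6-fold higher number from compound 2 to compound 3 (0.21 log units; that floor lies within the scatter). Compound 3 gives only a limit in this assay, so its exact place is not known; it is one of the compounds at the limit of > 100000 nM in this assay, at which 1 of the 3 values shown sits. On the numbers shown, compound 3 sits at the weak end, but no compound here can be set apart from the others.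

Compound 4 `S=C(NCc1ccccc1)N/N=C/c1ccc2ccccc2n1` carries the change (benzyl in place of 3-methylphenyl on an amide-type nitrogen). For the measured compounds named here, none of the measured steps concerns this kind of change: they all swap one small substituent for another on the aromatic ring, and none moved the number beyond the scatter. There is therefore no measured basis for expecting a step in either direction, and a result near the weak values seen so far is expected. The expected step is an at least 1.2-fold lower number from compound 3 to compound 4 (0.09 log units; that floor lies within the scatter). Compound 4 is estimated at 80000 nM, within a range from 20000 nM to 300000 nM.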

Compound 4, half-maximal inhibitory concentration: 53700 nM
For compound 4 the middle estimate is 1.5-fold (0.17 log units) above the measured one; the range from low to high includes it.
By their numbers in this assay, from the lowest: compounds 4, 2 and 1 (each within the scatter of the next). At a limit, above all of these: compound 3.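

In this assay, for the compounds shown here, the earlier steps only swapped one small ring substituent for another, whereas benzyl in place of a substituted phenyl changes how the ring is joined to the amide-type nitrogen, and even this larger change stays within the scatter: a 1.1-fold lower number from compound 2 to compound 4 (0.06 log units; within the scatter), and a 1.5-fold lower number from compound 1 to compound 4 (0.17 log units; within the scatter). The remaining step, an at least 1.8-fold lower number from compound 3 to compound 4 (0.27 log units; that floor lies within the scatter), gives only a floor that also lies within the scatter, so no real gap is established. Compound 3 remains a limit of the assay and not a number: the limit of > 100000 nM in this assay, at which 1 of the 4 values shown sits.

As far as these compounds go, it remains open whether any group on this nitrogen can move the number beyond the scatter, for example a longer chain such as phenethyl. Also open, from the compounds shown here alone, is what an amine or a carboxylic acid on the benzyl ring would do.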